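Methoxy to hydroxy on the compound 2 aryl group

The source may report more compounds than this note shows. Statements on the series, on what has been measured and on what is new or still open speak of the compounds shown alone.

Measured in a functional assay on HT-29 cells (Homo sapiens) for inhibition, with a stated time of 72 h; on this read-out higher numbers stand for weaker inhibition and lower numbers for stronger inhibition:
- Compound 1 `COc1ccc(S(=O)(=O)N2CCc3cccc(-c4ccc(F)nc4)c32)cc1`: 109 nM
- Compound 2 `COc1ccc(-c2cccc3c2N(S(=O)(=O)c2ccc(OC)cc2)CC3)cc1`: 277 nM
- Compound 3 `COc1ccc(S(=O)(=O)n2ccc3cccc(-c4ccc(F)cc4)c32)cc1`: 196 nM

In this assay compound 2 gives 277 nM, which lies within the scatter of compound 3 at 196 nM. Only compound 1, at 109 nM, stands beyond the scatter from compound 2, with a lower number.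

The next compound to be tested is compound 4 `COc1ccc(S(=O)(=O)N2CCc3cccc(-c4ccc(O)cc4)c32)cc1`. It keeps the core of compound 2 and changes one group: hydrogen in place of methyl on an oxygen on an aromatic ring. In words, this is hydrogen in place of methyl on an oxygen on an aromatic ring, turning 4-methoxyphenyl into 4-hydroxyphenyl.

Among the measured compounds shown here, one measured step bears on this group: a 2.5-fold higher number from compound 1 to compound 2 (0.41 log units; beyond the scatter). That step is modest, and it exchanges 6-fluoropyridin-3-yl for 4-methoxyphenyl, so it is only an indirect guide. For the measured compounds named here, no measured compound carries a hydroxy group, so the data give no direction for this change. Going by the values given here, with the step of a 2.5-fold higher number from compound 1 to compound 2 (0.41 log units; beyond the scatter) as the only guide, no shift beyond the scatter is expected.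

Compound 4 is estimated at 300 nM, with an expected range of 100 nM to 900 nM. The expected change is a 1.1-fold higher number from compound 2 to compound 4 (0.03 log units; within the scatter).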

Compound 4, half-maximal inhibitory concentration: 133 nM
Beside the measured number, compound 4's estimate is 2.3-fold (0.35 log units) above it, and the stated range covers the measured number.
By their numbers in this assay, from the lowest: compounds 1, 4, 3 and 2 (each within the scatter of the next, the first and the last beyond it).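

Working notes on the series: in this assay, removing the methyl from the oxygen on the aromatic ring gives a 2.1-fold lower number from compound 2 to compound 4 (0.32 log units; beyond the scatter), a modest step and the only direct reading of this change at this position, so the methyl on that oxygen is not needed to hold the number in this assay. The 4-aryl comparison also shifts: 4-methoxyphenyl stood apart from 6-fluoropyridin-3-yl by a 2.5-fold higher number from compound 1 to compound 2 (0.41 log units; beyond the scatter), whereas 4-hydroxyphenyl gives a 1.2-fold higher number from compound 1 to compound 4 (0.09 log units; within the scatter), so the hydroxy and fluoropyridine compounds cannot be told apart here. No measured data available for the series account for the step from methoxy to hydroxy.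

Still open, as far as these compounds go, is how an amine, a carboxylic acid or a longer chain such as ethoxy in place of the hydroxy group on this aryl ring would read in this assay. Also open, from the compounds shown here alone, is whether the same methoxy to hydroxy change would give a step of similar size on a different core, such as the core of compound 3.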